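The compounds below may be only part of what the source reports. "The series", "measured", "known", "first", "only" and "open" are said of these compounds alone.

Working notes on the series. Compound 1 `O=c1[nH]c(=O)c2ccc(-c3ccccc3)cc2[nH]1` and compound 2 `Nc1c2c(nn1-c1ccccc1)CC(=O)NC2=O` form the whole measured set. In an assay on isolated protein for inhibition of tyrosyl-DNA phosphodiesterase 2 (Homo sapiens), with a stated time of 15 min (on this read-out higher numbers stand for weaker inhibition and lower numbers for stronger inhibition), compound 1 gives > 111000 nM, which is a limit of the assay rather than a number. In this assay compound 2 gives > 111000 nM, also a limit and not a number. Compound 2 thus stands at the limit of > 111000 nM in this assay, at which 2 of the 2 values shown sit. Compound 3 `CC(=O)Nc1c2c(nn1-c1ccccc1)CC(=O)NC2=O` carries acetyl in place of hydrogen on a nitrogen on an aromatic ring. For the measured compounds named here, no pair of measured compounds differing in one place exists, so nothing measured sets the size of this step. The expected step is a number no higher from compound 2 to compound 3 (the limit leaves the size open), that is none beyond the scatter. The estimated value for compound 3 is 111000 nM, within 40000 nM to 300000 nM.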

Compound 3, half-maximal inhibitory concentration: > 111000 nM
Compound 3: no number, only a limit (the forecaster's own chance of this, stated with the estimate: 85%); the middle value lies on the limit itself.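

For the compounds shown here, compound 2 and compound 3 both give only limits in this assay, so no step between them can be read: the limit of > 111000 nM in this assay, at which 3 of the 3 values shown sit. The compounds shown leave open which change in structure, if any, would give a measurable inhibition.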